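Series notes: smaller group and new ring attachment on the core

A few compounds are considered here, and "the series" means these few. Any claim that something is new, unique, unknown or untested is made for them only; others in the source may bear on it.

Of the compounds shown here, three of the shared core have been measured in an assay on microsomes from brain for inhibition of Fatty-acid amide hydrolase 1 (Rattus norvegicus), read by fluorescence and HPLC, with a stated time of 60 min; on this read-out higher numbers stand for weaker inhibition and lower numbers for stronger inhibition. Compound 1 `CCCCCCCCc1ccc(OCC(=O)Cn2nnc(SC)n2)cc1` gives 31 nM and holds the lowest of the three numbers. Compound 3 `CCCCCCCCc1ccc(OCC(=O)Cn2nnc(Cc3ccccc3)n2)cc1` gives 66 nM, and compound 2 `CCCCCCCCc1ccc(OCC(=O)Cn2nnc(-c3cccc(S(=O)(=O)N(C)C)c3)n2)cc1` gives 420 nM. Both steps away from compound 1 raise the number: a 2.1-fold higher number from compound 1 to compound 3 (0.33 log units; beyond the scatter) and a 14-fold higher number from compound 1 to compound 2 (1.13 log units; beyond the scatter). Between the other two, a 6.4-fold lower number from compound 2 to compound 3 (0.80 log units; beyond the scatter).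

Compound 4 `CCCCCCCCc1ccc(OCC(=O)Cn2nnnc2C)cc1` has not yet been measured. Relative to compound 1 the change is 5-methyl-1H-tetrazol-1-yl in place of 5-(methylsulfanyl)-2H-tetrazol-2-yl on a saturated chain carbon bound to a carbonyl carbon. Going by the values given here, none of the measured steps covers this change directly: all three keep the same attachment of the five-membered ring to the chain carbon and vary only the group carried on that ring, and every group that entered in those steps was larger than methylsulfanyl. Those replacements gave modest to large rises in this assay. Among the compounds with values here, the change to compound 4 instead drops the methylsulfanyl group for a methyl and moves the point of attachment, and no measured compound shows what that does. A modest rise, with wide uncertainty, is therefore expected, so that a 2.6-fold higher number from compound 1 to compound 4 (0.41 log units; beyond the scatter) is the expected step. Compound 4 is estimated at 80 nM in this assay, with a range from 25 nM to 300 nM.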

Compound 4, half-maximal inhibitory concentration: 41 nM
The estimate for compound 4 lay 2.0-fold (0.29 log units) above the measured number, and the stated range covers the measured number.
By their numbers in this assay, from the lowest: compounds 1, 4 and 3 (each within the scatter of the next, the first and the last beyond it); then compound 2.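

In this assay, placing 5-methyl-1H-tetrazol-1-yl in place of 5-(methylsulfanyl)-2H-tetrazol-2-yl on a saturated chain carbon bound to a carbonyl carbon gives a 1.3-fold higher number from compound 1 to compound 4 (0.12 log units; within the scatter), so this exchange leaves the read-out within the scatter even though it alters both the ring attachment and the group carried on the ring. It is the only step from compound 1 shown so far that stays within the scatter, and the only one that alters the ring attachment, so the attachment seen in compound 1 is not required for a number of this size. Nothing available gives a reason for this result.

With both features altered in one step, the compounds shown cannot separate the contribution of the attachment from that of the group, and any effects of the two could have offset each other; 5-methyl-2H-tetrazol-2-yl and 5-(methylsulfanyl)-1H-tetrazol-1-yl are the groups that would divide the step. Also open, as far as these compounds go, is how the 1H-tetrazol-1-yl attachment responds to other groups on the ring, such as an ethyl, an amine or a carboxylic acid.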